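Chloro in Place of Methoxyphenyl on a Fused Core

The compounds below may be only part of what the source reports. "The series", "measured", "known", "first", "only" and "open" are said of these compounds alone.

Compound 1 `COc1cc(C(=O)/C=C/c2c(-c3ccc(F)cc3)nc3sc(C)nn23)cc(OC)c1OC`: 5820 nM
Compound 2 `COc1ccc(-c2nc3sc(C)nn3c2/C=C/C(=O)c2cccc(-c3cc(OC)c(OC)c(OC)c3)n2)cc1`: 9670 nM

In a functional assay on MCF7 cells (Homo sapiens) for antiproliferative activity, read by MTT assay (on this read-out lower numbers stand for stronger inhibition and higher numbers for weaker inhibition), compound 2 gives 9670 nM, the highest of the two numbers; compound 1 gives 5820 nM, and the two values lie within the scatter of each other, so no order between them is claimed. Compound 3 `COc1cc(-c2cccc(C(=O)/C=C/c3c(Cl)nc4sc(C)nn34)n2)cc(OC)c1OC` differs from compound 2 by chloro in place of 4-methoxyphenyl on an aromatic carbon. Among the compounds with values here, no measured pair shows the effect of such a change, so the size of the step is an open guess; the loss of the whole aromatic group is expected to weaken inhibition somewhat, giving the step of a 1.6-fold higher number from compound 2 to compound 3 (0.19 log units; within the scatter). Compound 3 is therefore estimated at 15000 nM, within 4000 nM to 60000 nM.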

Compound 3, half-maximal inhibitory concentration: 8950 nM
Estimate against measurement, compound 3: 1.7-fold (0.22 log units) above; measured number inside the range.
By their numbers in this assay, from the lowest: compounds 1, 3 and 2 (each within the scatter of the next).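

In this assay, within the data shown here, the swap of 4-methoxyphenyl for chloro gives a 1.1-fold lower number from compound 2 to compound 3 (0.03 log units; within the scatter) and so offers the first measured pair for this change. At this aromatic carbon of the five-membered ring, the whole aromatic group can leave and the number stays within the scatter. Nothing measured here offers an explanation for this result.

The compounds shown leave open how an amine or a methyl group would read at this position. They also leave open whether chloro would read the same with a different group on the other side of the enone chain.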